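Dropping the methoxy from compound 1

The source may hold more compounds than are shown below. What is called first, only, known or untested is meant among the compounds shown, and "the series" means these compounds.

Compound 1 `COc1ccccc1NC(=O)N[C@H]1CC[C@H](Oc2ccc(F)cc2)CC1` in a functional assay on CRL2813 cells (Homo sapiens) for cytotoxicity, read by sulforhodamine B assay, with a stated time of 5 days (on this read-out lower numbers stand for stronger inhibition and higher numbers for weaker inhibition), gives only the assay limit of > 20000 nM, not a number. Compound 1 therefore stands with the weaker members of the series. Compound 2 `O=C(Nc1cccc(C(F)(F)F)c1)N[C@H]1CC[C@H](Oc2ccccc2F)CC1` gives 2450 nM in this assay. Compound 3 `O=C(Nc1cccc(C(F)(F)F)c1)N[C@H]1CC[C@H](O)CC1` reaches only the limit of > 20000 nM in this assay. For the measured compounds named here, the single step between measured compounds, an at least 8.1-fold higher number from compound 2 to compound 3 (0.91 log units; beyond the scatter), changes a different part of the molecule and does not bear on the present change. Compound 4 `O=C(Nc1ccccc1)N[C@H]1CC[C@H](Oc2ccc(F)cc2)CC1` differs from compound 1 by hydrogen in place of methoxy on an aromatic carbon. Going by the values given here, no measured step covers this change, and the limit of > 20000 nM in this assay, at which 2 of the 3 values shown sit, shows how little the series yet resolves. No step beyond the scatter is expected in this assay, in either direction. Compound 4 is estimated at 20000 nM, within 5000 nM to 80000 nM, with an expected step of a number no higher from compound 1 to compound 4 (the limit leaves the size open).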

Compound 4, half-maximal inhibitory concentration: 20000 nM
Compound 4: the middle estimate sits on the measured number at the digits printed; the measured number falls inside the stated range.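

With hydrogen in place of methoxy, this position gives its first actual number, as compound 4 gives 20000 nM in this assay. Compound 1 gives > 20000 nM, which is a limit and not a number. The result, a number no higher from compound 1 to compound 4 (the limit leaves the size open), therefore shows no measurable effect of the methoxy, and the series remains poorly resolved at this end: the limit of > 20000 nM in this assay, at which 2 of the 4 values shown sit.

Still open, as far as these compounds go, is whether an amine or a carboxylic acid in place of the methoxy would give a number clearly lower than that of compound 4.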